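A few compounds are considered here, and "the series" means these few. Any claim that something is new, unique, unknown or untested is made for them only; others in the source may bear on it.

Measured in an ADME assay on microsomes from liver (Homo sapiens), read by LC-MS, using NADPH, with a stated time of 10 min, tested at 0.5 uM; on this read-out lower numbers stand for a less stable compound and higher numbers for a more stable compound:
- compound 1 `Cc1nc2cc(-c3ccc(OCc4ccccc4)cc3)nn2c(-c2cc(F)c3c(c2C)CCCO3)c1C(OC(C)(C)C)C(=O)O`: 84%
- compound 2 `Cc1nc2cc(-c3cccc(OCc4ccccc4)c3)nn2c(-c2cc(F)c3c(c2C)CCCO3)c1C(OC(C)(C)C)C(=O)O`: 72%
- compound 3 `Cc1ccccc1-c1cccc(-c2cc3nc(C)c([C@H](OC(C)(C)C)C(=O)O)c(-c4cc(F)c5c(c4C)CCCO5)n3n2)c1`: 95%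

Compound 3 stands highest of the three, beyond the scatter of both other compounds. Next in the series is compound 4 `Cc1nc2cc(-c3cccc(-c4ccccc4F)c3)nn2c(-c2cc(F)c3c(c2C)CCCO3)c1[C@H](OC(C)(C)C)C(=O)O`. Its difference from compound 3 is fluoro in place of methyl on an aromatic carbon, ortho to a large group. Among the measured compounds shown here, no measured pair shows this change or any other single change, so the expectation is weakly founded. With compound 3 at 95% in this assay, little room remains upward. The expected change is a number 3 percentage points lower from compound 3 to compound 4 (within the scatter), and no step beyond the scatter is expected. For compound 4 the estimate is 92%, with an expected range of 80% to 99%.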

Compound 4, percent of the compound remaining: 100%
The estimate for compound 4 lay 8 percentage points below the measured number, and the stated range ends below it.
By their numbers in this assay, from the lowest: compound 2; then compound 1; then compounds 3 and 4 (each within the scatter of the next).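

In this assay, among the compounds shown here, 2-methylphenyl to 2-fluorophenyl gives the first single-place step, a number 5 percentage points higher from compound 3 to compound 4 (within the scatter), so fluoro and methyl on this aromatic carbon, ortho to a large group, cannot be told apart on this read-out. Both compounds stand so close to the top of the scale that any further gain from this change could hardly show. No evidence bears on what lies behind this result.

From the compounds shown here alone, whether a chloro, a methoxy or an amine at this place would hold the read-out stays open.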